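Methyl to Fluoro on the Sulfonamide Ring, Second Core

This account rests on a few compounds, and the source may have more. Where it says the series, first, only, none or still open, it means among the compounds named here.

Compound 1, `COc1ncc(-c2ccc3nc(N)nn3c2)cc1NS(=O)(=O)c1ccc(F)cc1`: 1930 nM
Compound 2, `COc1ncc(-c2ccc3nc(N)nn3c2)cc1NS(=O)(=O)c1ccc(C)cc1`: 1550 nM
Compound 3, `COc1ncc(-c2ccn3nc(NC(C)=O)nc3c2)cc1NS(=O)(=O)c1ccc(C)cc1`: 1360 nM

Of the compounds shown here, three have been measured in a functional assay on MCF7 cells (Homo sapiens) for antiproliferative activity, read by MTT assay, with a stated time of 48 h; a lower number here means a stronger inhibitor, a higher number a weaker inhibitor. Compound 1 and compound 2 share one core and differ only in the sulfonamide aryl ring: fluoro in place of methyl on an aromatic carbon. That change gives a 1.2-fold higher number from compound 2 to compound 1 (0.10 log units; within the scatter), so the two values are within the scatter of each other and no order between them can be read. Compound 3 carries a different core; the difference between the two cores is not broken down here. In this assay compound 3 gives 1360 nM, which is within the scatter of both compound 2 and compound 1.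

Compound 4, `COc1ncc(-c2ccn3nc(NC(C)=O)nc3c2)cc1NS(=O)(=O)c1ccc(F)cc1`, is not yet measured. It differs from compound 3 by fluoro in place of methyl on an aromatic carbon, at a place described in the same words as the place where compound 1 differs from compound 2, so it is the same change made on the core of compound 3 instead of the core of compound 2.

The expectation for compound 4 rests on that earlier pair: because a 1.2-fold higher number from compound 2 to compound 1 (0.10 log units; within the scatter) stayed within the scatter, the step from compound 3 to compound 4 is expected to be of the same small size, a 1.2-fold higher number from compound 3 to compound 4 (0.08 log units; within the scatter). On that basis compound 4 is estimated to give 1650 nM in this assay, with an expected range from 900 nM to 3000 nM.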

Compound 4, half-maximal inhibitory concentration: 1730 nM
Estimate against measurement, compound 4: 1.0-fold (0.02 log units) below, within the range that was stated.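

In this assay, putting fluoro in place of methyl on the sulfonamide aryl ring of the core of compound 3 gives a 1.3-fold higher number from compound 3 to compound 4 (0.10 log units; within the scatter), so no order can be read between compound 3 and compound 4. Set beside the same change on the core of compound 2, the step carries over to the second core with no difference that can be read: the same change on two cores in this assay, a 1.2-fold higher number (0.10 log units; within the scatter) from compound 2 to compound 1 and a 1.3-fold higher number (0.10 log units; within the scatter) from compound 3 to compound 4, 1.0-fold (0.01 log units) apart, within the scatter of two such steps. This shows that, on these two cores and in this one cell assay, going from 4-methylphenyl to 4-fluorophenyl leaves the number within the scatter, but it does not show that either group is the better one, and two small steps that agree say nothing about how the change would behave on any further core or in any other assay.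

The compounds shown hold only methyl and fluoro at this place on the ring, so it remains open what a chloro, a methoxy, a trifluoromethyl, an amine or a carboxylic acid would do there, and whether any such group would give a step beyond the scatter. Going by these compounds, the two cores also differ from each other in more than one place, so what each of those differences contributes on its own stays open as well.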